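Cyclopropyl in place of methyl: compound 2 to compound 3

The source may report more compounds than this note shows. Statements on the series, on what has been measured and on what is new or still open speak of the compounds shown alone.

Measured so far in a functional assay on the whole organism with Mus musculus as the target; a lower number here means that less compound is needed, a higher number that more compound is needed for the effect:
compound 1 `Cc1nnc(CNC(=O)CN)n1-c1ccc(Cl)cc1C(=O)c1ccccc1F`: 0.09 mg/kg
compound 2 `Cc1nnc(CNC(=O)CN)n1-c1ccc(Cl)cc1C(=O)c1ccccc1Cl`: 0.26 mg/kg

Of these two, compound 2 at 0.26 mg/kg holds the higher number, so more of it is needed for the effect than of compound 1. The next compound, compound 3 `NCC(=O)NCc1nnc(C2CC2)n1-c1ccc(Cl)cc1C(=O)c1ccccc1Cl`, keeps everything in compound 2 except for one change, cyclopropyl in place of methyl on an aromatic carbon and has not yet been measured.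

Among the measured compounds shown here, only one measured step exists, and it is a 2.9-fold higher number from compound 1 to compound 2 (0.46 log units; beyond the scatter), a modest change with chloro in place of fluoro on an aromatic carbon. That step does not touch the site now being altered, so it shows only how large a single substitution in this series can be. No measurement reports what happens when methyl is replaced. With so little evidence, the expected change is small, and the lean towards a higher number is only slight. The expected step is a 1.5-fold higher number from compound 2 to compound 3 (0.19 log units; within the scatter) and it is not expected to lie clearly beyond the scatter. Compound 3 is estimated at 0.4 mg/kg with an expected range from 0.13 mg/kg to 1.2 mg/kg.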

Compound 3, dose for half-maximal effect: 0.88 mg/kg
Compound 3: middle estimate off by 2.2-fold (0.34 log units), on the low side; low and high end bracket the measured number.
By their numbers in this assay, from the lowest: compound 1; then compound 2; then compound 3.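

The change at this position, on the aromatic carbon between two ring nitrogen atoms, gives a 3.4-fold higher number from compound 2 to compound 3 (0.53 log units; beyond the scatter) in this assay, so this site, which the earlier step left untouched, also affects how much compound is needed. Going from methyl, with 1 heavy atom, to cyclopropyl, with 3 heavy atoms and a three-membered ring, moves the number upward, and this step, like the chloro for fluoro step, a 2.9-fold higher number from compound 1 to compound 2 (0.46 log units; beyond the scatter), lies beyond the scatter. No measurement accompanying these compounds bears on what lies behind the result.

The compounds shown leave open whether the higher number goes with the added carbon atoms or with the ring itself, a question that an open chain such as ethyl or isopropyl at the same place would address, while a plain hydrogen there would show the trend on the smaller side of methyl. Going by these compounds, it also remains open whether cyclopropyl in place of methyl would give a similar step in compound 1, which carries fluoro where compound 2 carries chloro.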